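The source may report more compounds than this note shows. Statements on the series, on what has been measured and on what is new or still open speak of the compounds shown alone.

Measured compounds:
- compound 1 `O=C(/C=C/c1cn(-c2ccccc2)nc1-c1cccnc1)c1ccccn1` gives 2100 nM in a functional assay on HCT-116 cells (Homo sapiens) for inhibition, read by sulforhodamine B assay, with a stated time of 72 h; on this read-out lower numbers stand for stronger inhibition and higher numbers for weaker inhibition
- compound 2 `COc1cc(OC)c(C(=O)/C=C/c2cn(-c3ccccc3)nc2-c2cccnc2)c(OC)c1` gives 300 nM in this assay

Compound 1 has the highest of the two numbers in this assay; compound 2 sits at a lower number, and the gap between the two lies beyond the usual scatter. Both compounds share the same core, differing only in the aryl group on the carbonyl carbon.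

Compound 3 `COc1ccc(OC)c(C(=O)/C=C/c2cn(-c3ccccc3)nc2-c2cccnc2)c1` is not yet measured in this assay. Relative to compound 1 the change is 2,5-dimethoxyphenyl in place of pyridin-2-yl on a carbonyl carbon. For the measured compounds named here, no step between measured compounds covers exactly this change, but the two values shown for compound 1 and compound 2 suggest that a methoxy-bearing phenyl group at this position goes with a lower number than the pyridin-2-yl group.

For compound 3 in this assay a number below that of compound 1 is expected, a step of a 4.2-fold lower number from compound 1 to compound 3 (0.62 log units; beyond the scatter) beyond the scatter, with compound 3 estimated at 500 nM and a range of 150 nM to 1800 nM.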

Compound 3, half-maximal inhibitory concentration: 1000 nM
The estimate for compound 3 lay 2.0-fold (0.30 log units) below the measured number; measured number inside the range.
By their numbers in this assay, from the lowest: compound 2; then compound 3; then compound 1.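

In this assay, the step with 2,5-dimethoxyphenyl in place of pyridin-2-yl on a carbonyl carbon is a 2.1-fold lower number from compound 1 to compound 3 (0.32 log units; beyond the scatter), so this direct comparison shows a modest gain at this position. The methoxy-bearing aryl groups do not give the same number: compound 3 gives 1000 nM, while compound 2 gives 300 nM, so the identity of the aryl group still matters beyond the presence of methoxy groups. No measurement shown here gives a reason for the step from the pyridin-2-yl group to the 2,5-dimethoxyphenyl group.

From the compounds shown here alone, whether the methoxy groups are needed at all remains open, as an unsubstituted phenyl group at this position would be required to separate their contribution from that of the ring change. Also open, going by these compounds, is how a single methoxy group or an amine on the phenyl ring would compare.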